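Methyl to Fluoro: One Small Swap on a Shared Core

This account rests on a few compounds, and the source may have more. Where it says the series, first, only, none or still open, it means among the compounds named here.

Compound 1 `c1cc(Nc2nccc(-c3ccncc3)n2)cc(OCCn2ccnc2)c1`: 200 nM
Compound 2 `Cc1cccc(Nc2nccc(-c3ccncc3)n2)c1`: 8800 nM

In a functional assay for inhibition, with Homo sapiens as the target (on this read-out lower numbers stand for stronger inhibition and higher numbers for weaker inhibition), compound 2 gives 8800 nM, the highest number of the two measured, while its nearest neighbour, compound 1, gives 200 nM. Compound 3 `Fc1cccc(Nc2nccc(-c3ccncc3)n2)c1` differs from compound 2 by fluoro in place of methyl on an aromatic carbon. Going by the values given here, the only measured step, a 44-fold higher number from compound 1 to compound 2 (1.64 log units; beyond the scatter), concerns a different group and does not bear on this swap. Among the compounds with values here, no measured step shows what fluoro in place of methyl does here, so the step of a 1.1-fold lower number from compound 2 to compound 3 (0.04 log units; within the scatter) is expected to stay within the scatter. Compound 3 is therefore estimated at 8000 nM, in a range from 3000 nM to 25000 nM.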

Compound 3, half-maximal inhibitory concentration: 700 nM
Estimate against measurement, compound 3: 11-fold (1.06 log units) above; measured number outside the range, below it.
By their numbers in this assay, from the lowest: compound 1; then compound 3; then compound 2.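

In this assay, fluoro in place of methyl gives a 13-fold lower number from compound 2 to compound 3 (1.10 log units; beyond the scatter), so this place on the aromatic ring responds strongly to a change between two groups of one heavy atom each. The long 2-(1H-imidazol-1-yl)ethoxy group is thus not the only route to a low number here, although fluoro in its place still leaves a 3.5-fold higher number from compound 1 to compound 3 (0.54 log units; beyond the scatter). Nothing available explains why fluoro and methyl differ so much.

Going by these compounds, how an amine, a chloro group or a shorter ether chain would behave at this place remains open.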